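Cytotoxicity notes on compounds 1 to 3

The source may hold more compounds than are shown below. What is called first, only, known or untested is meant among the compounds shown, and "the series" means these compounds.

Measured so far in a functional assay on Huh-7 cells (Homo sapiens) for cytotoxicity, read by MTT assay, with a stated time of 3 days; a higher number here means that more compound is tolerated, a lower number that less compound is tolerated:
compound 1, `OC[C@H]1O[C@@H](n2cnc3c(COc4ccccc4)ncnc32)[C@H](O)[C@@H]1O`, gives > 100000 nM.
Compound 2, `CC(=O)N(Cc1ncnc2c1ncn2[C@H]1C[C@H](O)[C@@H](CO)O1)C1CCCCC1`, gives > 100000 nM.

For compound 1 the value > 100000 nM is a limit of the assay and not a number, so its standing on the scale is known only as that limit. The value of compound 2 in this assay, > 100000 nM, is likewise a limit. Going by the values given here, with no number on either side, no step between measured compounds can be worked out; what the two values show is the limit of > 100000 nM in this assay, at which 2 of the 2 values shown sit.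

Compound 3, `OC[C@H]1O[C@@H](n2cnc3c(Cn4cccn4)ncnc32)[C@H](O)[C@@H]1O`, is not yet measured. It differs from compound 1 by 1H-pyrazol-1-yl in place of phenoxy on a saturated chain carbon bound to an aromatic carbon; the rest of compound 1 is kept unchanged.

Because compound 1 sits at the limit of > 100000 nM in this assay, at which 2 of the 2 values shown sit, no step beyond the scatter is expected in this assay, and the step is estimated as a number no higher from compound 1 to compound 3 (the limit leaves the size open). For compound 3 the expected value in this assay is 100000 nM, with a range from 50000 nM to 300000 nM, and most likely the assay again reports only a limit rather than a number.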

Compound 3, half-maximal cytotoxic concentration: > 250000 nM
Compound 3 gave a limit, no number; the forecaster's own chance of this, stated with the estimate: 85%; middle value at least 2.5-fold (0.39 log units) from the limit.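

In this assay compound 3 gives > 250000 nM, a limit and not a number. Going by these compounds alone, compound 1 also stands at a limit, and no step between compound 1 and compound 3 can be read. The compounds shown leave open whether 1H-pyrazol-1-yl in place of phenoxy changes the tolerated concentration at all.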